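Chain Length and Cytotoxicity in a Bicyclic Nucleoside-Like Series

The source may hold more compounds than are shown below. What is called first, only, known or untested is meant among the compounds shown, and "the series" means these compounds.

Compound 1 `CCCCc1cc2cn(COCCO)c(=O)nc2o1` carries a butyl chain on the shared core. In a functional assay on HEL cells (Homo sapiens), read by microscopy (on this read-out lower numbers stand for higher toxicity in this test and higher numbers for lower toxicity in this test), compound 1 gives > 400000 nM, which is a limit of the test and not a number. For the measured compounds named here, this is the only result for compound 1, so it stands only at the limit (the limit of > 400000 nM in this assay, at which 1 of the 2 values shown sits). Compound 2 `CCCCCCCCCCCc1cc2cn(COCCO)c(O)nc-2n1` carries an undecyl chain on a differently drawn form of the core; in this assay compound 2 gives 80000 nM.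

Compound 3 `CCCCCCCCCCc1cc2cn(COCCO)c(=O)nc2o1` is not yet measured. It differs from compound 1 by hexyl in place of hydrogen on a saturated chain carbon, four bonds along the chain from an aromatic carbon. Going by the values given here, no step between two measured compounds is known here, so the size of the change is open. Compound 2, the other compound with a long chain, gives a number rather than a limit, and on that basis the step is expected to run toward higher toxicity, as an at least 4.0-fold lower number from compound 1 to compound 3 (0.60 log units; beyond the scatter). In this assay compound 3 is therefore expected to give about 100000 nM, within a range from 30000 nM to 400000 nM, with a fair chance that only a limit is again reported.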

Compound 3, minimum cytotoxic concentration: 400000 nM
For compound 3 the middle estimate is 4.0-fold (0.60 log units) below the measured one; the measured number falls inside the stated range.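

In this assay, for the compounds shown here, compound 3 gives 400000 nM, so the chain position on the shared core can yield a number, whereas the only earlier number came from compound 2, on a differently drawn form of the core. Hexyl in place of hydrogen on a saturated chain carbon, four bonds along the chain from an aromatic carbon, gives a number no higher from compound 1 to compound 3 (the limit leaves the size open), which fixes a direction that includes no change but no size. The step cannot be read as a size, since one end of it is a limit of the test and not a number: the limit of > 400000 nM in this assay, at which 1 of the 3 values shown sits.

The compounds shown leave open how the read-out in this assay moves with chain length on the shared core, since a single pair with one limit defines no trend and a longer chain could continue or reverse the direction. They also leave open whether the chain position tolerates something other than a plain alkyl chain, such as a chain carrying an amine or a carboxylic acid.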